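This account rests on a few compounds, and the source may have more. Where it says the series, first, only, none or still open, it means among the compounds named here.

Series in a functional assay on the whole organism with Rattus norvegicus as the target; a higher number here means that more compound is needed for the effect, a lower number that less compound is needed:
Compound 1 `CCCCn1c(=N)sc2cc(OC(F)(F)F)ccc21`: 10 mg/kg
Compound 2 `COC(=O)Cn1c(=N)sc2cc(OC(F)(F)F)ccc21`: > 10 mg/kg

Compound 2 stands at > 10 mg/kg, which is a limit and not a number.

Compound 3 `CCN(CC)C(=O)Cn1c(=N)sc2cc(OC(F)(F)F)ccc21` follows from compound 2 by diethylamino in place of methoxy on a carbonyl carbon, which turns methoxycarbonyl into diethylcarbamoyl. For the measured compounds named here, the only measured step, a number no lower from compound 1 to compound 2 (the limit leaves the size open), bears on this side chain, but its size stays open. Going by the values given here, no measured step covers a change on the carbonyl carbon. Among the compounds with values here, compound 1, at 10 mg/kg, gives the only number to anchor the expectation. The expected change, weakly held, is an at least 1.4-fold lower number from compound 2 to compound 3 (0.15 log units; that floor lies within the scatter), towards less compound needed. For compound 3 the estimated value is 7 mg/kg, with an expected range of 2 mg/kg to 25 mg/kg.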

Compound 3, dose for half-maximal effect: 9 mg/kg
For compound 3 the middle estimate is 1.3-fold (0.11 log units) below the measured one, and the stated range covers the measured number.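

Diethylamino in place of methoxy on a carbonyl carbon gives an at least 1.1-fold lower number from compound 2 to compound 3 (0.04 log units; that floor lies within the scatter) in this assay, so the size of this step stays unresolved. Compound 2 is held only by a limit: the limit of > 10 mg/kg in this assay, at which 1 of the 3 values shown sits.

Diethylcarbamoyl in place of propyl gives a 1.1-fold lower number from compound 1 to compound 3 (0.05 log units; within the scatter), so compound 3 shows that a carbonyl-bearing side chain at this position can give a measured number matching that of the plain chain within the scatter.

On these data alone, whether a carboxylic acid in place of methoxycarbonyl, or a longer chain in place of propyl, would move the number beyond the scatter stays open.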